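Switching the Pendant Aryl Group on a Biaryl Benzyl Alcohol

The source may hold more compounds than are shown below. What is called first, only, known or untested is meant among the compounds shown, and "the series" means these compounds.

Measured so far:
compound 1, `CC(C)c1cc(C(C)(C)C)cc(-c2ccc(F)cc2)c1CO`, in a functional assay on RKE cells for antagonist activity at Vasoactive intestinal polypeptide receptor 1 (Rattus norvegicus), read by HTRF and cAMP accumulation, with stated times of 10 min and 30 min (a lower number here means a stronger inhibitor, a higher number a weaker inhibitor), compound 1 gives 740 nM
compound 2, `CC(C)c1cc(C(C)(C)C)cc(-c2ccc(Cl)cc2)c1CO`, in this assay compound 2 gives 290 nM

Compound 2 stands lowest of the two numbers recorded; its nearest neighbour is compound 1, separated from it by a 2.6-fold lower number from compound 1 to compound 2 (0.41 log units; beyond the scatter). For the measured compounds named here, that single step, brought by chloro in place of fluoro on an aromatic carbon, is the only measured change and was modest.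

Compound 3, `Cc1cccc(-c2cc(C(C)(C)C)cc(C(C)C)c2CO)c1`, differs from compound 2 by 3-methylphenyl in place of 4-chlorophenyl on an aromatic carbon. Going by the values given here, no measured step covers a change of this kind: the halogen swap between compound 1 and compound 2 touched neither the methyl nor its placement, so it only loosely bears on compound 3. With the direction unknown, the step of a 1.7-fold higher number from compound 2 to compound 3 (0.24 log units; within the scatter) is expected to lie within or just beyond the scatter. Compound 3 is therefore estimated at 500 nM, with a range from 150 nM to 1800 nM.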

Compound 3, half-maximal inhibitory concentration: 240 nM
For compound 3 the middle estimate is 2.1-fold (0.32 log units) above the measured one, and the stated range covers the measured number.
By their numbers in this assay, from the lowest: compounds 3 and 2 (each within the scatter of the next); then compound 1.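

In this assay the position ortho to the hydroxymethyl group accepts 3-methylphenyl in place of 4-chlorophenyl with a 1.2-fold lower number from compound 2 to compound 3 (0.08 log units; within the scatter) and so, among the compounds shown, a halogen on the pendant ring is not needed to keep the number at this level. The same group set against 4-fluorophenyl gives a 3.1-fold lower number from compound 1 to compound 3 (0.49 log units; beyond the scatter) and this leaves compound 1 apart from the other two, so that 4-fluorophenyl, not the absence of a halogen, is what stands out among these three rings. Nothing available explains why these rings read as they do.

The last swap changes both the substituent and its place on the pendant ring, so the two cannot be told apart without 4-methylphenyl or 3-chlorophenyl. On these data alone, how an unsubstituted phenyl, or a ring carrying an amine or a carboxylic acid, would read at this position also stays open.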